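Swapping the benzylic aryl group on a shared quinoline-free core

The source may report more compounds than this note shows. Statements on the series, on what has been measured and on what is new or still open speak of the compounds shown alone.

Compound 1 `COc1cccc(Oc2ccc3c(NCCCNCc4ccco4)ccnc3c2)c1` gives 15500 nM in an ADME assay on HepG2 cells (Homo sapiens) for cytotoxicity, read by luminescence, CellTiter-Glo and ATP content, with a stated time of 72 h; a higher number here means that more compound is needed for the effect, a lower number that less compound is needed. Among the measured compounds shown here, compound 2 `c1ccc(Cc2ccc3c(NCCCNCc4ccco4)ccnc3c2)cc1` gives 16000 nM in this assay, and the one measured step, a 1.0-fold higher number from compound 1 to compound 2 (0.01 log units; within the scatter), stays within the scatter. Compound 3 `COc1ccc(F)cc1CNCCCNc1ccnc2cc(-c3cccc4ccccc34)ccc12` gives 16000 nM in this assay, level with compound 2 at the digits shown and within the scatter of compound 1. Compound 4 `c1coc(CNCCCNc2ccnc3cc(-c4cccc5ccccc45)ccc23)c1` differs from compound 3 by furan-2-yl in place of 5-fluoro-2-methoxyphenyl on a saturated chain carbon bound to an amine nitrogen. For the measured compounds named here, no measured step touches this chain position; the only step available, between compounds 1 and 2, exchanged an aryl group elsewhere without effect beyond the scatter. Compound 4 is therefore expected to sit near compound 3, the step of no change at the digits printed from compound 3 to compound 4 (within the scatter) being estimated as none beyond the scatter. The estimate for compound 4 is 16000 nM, with a range from 8000 nM to 32000 nM.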

Compound 4, half-maximal effective concentration: 5600 nM
Estimate against measurement, compound 4: 2.9-fold (0.46 log units) above; the whole stated range lies above it.
By their numbers in this assay, from the lowest: compound 4; then compounds 1, 2 and 3 (each within the scatter of the next).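

Among the compounds shown here, with furan-2-yl in place of 5-fluoro-2-methoxyphenyl on a saturated chain carbon bound to an amine nitrogen, the result is a 2.9-fold lower number from compound 3 to compound 4 (0.46 log units; beyond the scatter) in this assay, the first step beyond the scatter and the first at this position. With furan-2-yl kept, naphthalen-1-yl on the aromatic carbon also gives a 2.9-fold lower number from compound 2 to compound 4 (0.46 log units; beyond the scatter) and a 2.8-fold lower number from compound 1 to compound 4 (0.44 log units; beyond the scatter), whereas benzyl in place of 3-methoxyphenoxy stayed within the scatter. Nothing at hand bears on why these numbers differ. As far as these compounds go, whether a thiophene or pyridine ring on that chain carbon would behave like furan-2-yl remains open. So does the effect of a longer chain between the two amine nitrogens.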